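The source may hold more compounds than are shown below. What is called first, only, known or untested is meant among the compounds shown, and "the series" means these compounds.

In a functional assay on K562 cells (Homo sapiens) for antiproliferative activity, read by MTT assay, with a stated time of 72 h (a higher number here means a weaker inhibitor, a lower number a stronger inhibitor), compound 1 (`COc1cc(C(=O)c2sc3ccccc3c2-c2ccccc2)cc(OC)c1OC`) gives 2100 nM and compound 2 (`COc1cc(C(=O)c2sc3ccccc3c2Nc2ccc(C)cc2)cc(OC)c1OC`) gives 1600 nM and the two values lie within the scatter of each other. Compound 3 (`CCOc1ccc(Nc2c(C(=O)c3cc(OC)c(OC)c(OC)c3)sc3ccccc23)cc1`) carries ethoxy in place of methyl on an aromatic carbon, para to a large group (ethoxy in place of methyl on an aromatic carbon). Among the measured compounds shown here, the one measured step (a 1.3-fold lower number from compound 1 to compound 2 (0.12 log units; within the scatter)) replaces phenyl with (4-methylphenyl)amino and does not touch this methyl, so it gives little guide, and no change beyond the scatter is expected in this assay here. The estimated step is small (a 1.3-fold lower number from compound 2 to compound 3 (0.12 log units; within the scatter)). Compound 3 is expected at 1200 nM (estimated range 300 nM to 4000 nM).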

Compound 3, half-maximal inhibitory concentration: 200 nM
Compound 3: the middle estimate sits 6.0-fold (0.78 log units) above what was measured; the measured number lies below the stated range.
By their numbers in this assay, from the lowest: compound 3; then compounds 2 and 1 (each within the scatter of the next).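

In this assay, the outer end of the (4-methylphenyl)amino group matters: ethoxy in place of methyl on this aromatic carbon, para to a large group, gives a clear gain (an 8.0-fold lower number from compound 2 to compound 3 (0.90 log units; beyond the scatter)). The full change to (4-ethoxyphenyl)amino in place of phenyl gives a gain of similar order (an 11-fold lower number from compound 1 to compound 3 (1.02 log units; beyond the scatter)), so among these compounds the improvement appears only once ethoxy is present. Nothing available explains this gain.

Going by these compounds, whether the oxygen or the added length counts remains open, and methoxy or ethyl at this position could separate the two. On these data alone, how a longer chain such as propoxy, or an amine, would behave here is also open.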